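Two Cores, One Chain Change

A few compounds are considered here, and "the series" means these few. Any claim that something is new, unique, unknown or untested is made for them only; others in the source may bear on it.

Measured so far:
compound 1 `O=C(NCCCCc1ccccc1)Nc1nc2ccccc2[nH]1`: > 10000 nM
compound 2 `O=C(NCCCCc1ccccc1)n1cnc2ccccc21`: 2.5 nM
compound 3 `CCCCCCNC(=O)n1cnc2ccccc21`: 6.6 nM

The read-out throughout is an assay on HEK293 cells for inhibition of acid ceramidase (Homo sapiens), read by fluorescence, with stated times of 30 min and 1 h; a lower number here means a stronger inhibitor, a higher number a weaker inhibitor. Compound 2 gives 2.5 nM and compound 3 gives 6.6 nM; the step between them is a 2.6-fold higher number from compound 2 to compound 3 (0.42 log units; beyond the scatter), the change being (ethyl in place of phenyl on a saturated chain carbon, four bonds along the chain from an amide-type nitrogen). Compound 1 reaches only the limit of this assay, > 10000 nM. It therefore stands at the limit of > 10000 nM in this assay, at which 1 of the 3 values shown sits. How the core of compound 1 differs from the core of compound 2 is not broken down here. Compound 4 `CCCCCCNC(=O)Nc1nc2ccccc2[nH]1` is still unmeasured; it carries the same change on the core of compound 1, (ethyl in place of phenyl on a saturated chain carbon, four bonds along the chain from an amide-type nitrogen). The expectation for compound 4 rests on the modest weakening seen in a 2.6-fold higher number from compound 2 to compound 3 (0.42 log units; beyond the scatter), applied to a starting point that is itself only a limit. Compound 4 is therefore expected to remain at or past that limit, an estimated step that the limit leaves unreadable from compound 1 to compound 4. The estimated value for compound 4 is 25000 nM.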

Compound 4, half-maximal inhibitory concentration: > 10000 nM
Compound 4 gave a limit, no number; the forecaster's own chance of this, stated with the estimate: 85%; the middle value is on the limit's open side.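

For the compounds shown here, compound 1 and compound 4 both return limits rather than numbers, so no step between them can be read: the limit of > 10000 nM in this assay, at which 2 of the 4 values shown sit. The compounds shown leave open whether ethyl in place of phenyl changes anything on the core of compound 1.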